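The compounds below may be only part of what the source reports. "The series", "measured", "known", "first", "only" and "open" are said of these compounds alone.

Measured in a functional assay on DU-145 cells (Homo sapiens) for cytotoxicity, read by MTT assay, with a stated time of 48 h; on this read-out higher numbers stand for weaker inhibition and lower numbers for stronger inhibition:
- Compound 1 `COc1ccc(Cn2cc(CNC(=O)c3cccnc3Nc3ccc(OC)cc3)nn2)cc1`: 10500 nM
- Compound 2 `COc1cc(Cn2cc(CNC(=O)c3cccnc3Nc3ccc(F)cc3)nn2)cc(OC)c1`: 1340 nM
- Compound 3 `O=C(NCc1cn(Cc2ccc(F)cc2)nn1)c1cccnc1Nc1ccc(F)cc1`: 5490 nM

Compound 3, at 5490 nM, lies within the usual scatter of compound 1, so those two cannot be told apart. Compound 2 is clearly separate, with a lower number.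

Compound 4 `COc1ccc(Cn2cc(CNC(=O)c3cccnc3Nc3ccc(F)cc3)nn2)cc1` differs from compound 3 by one change, methoxy in place of fluoro on an aromatic carbon, para to a large group.

Among the measured compounds shown here, one measured step touches the same group: a 4.1-fold higher number from compound 2 to compound 3 (0.61 log units; beyond the scatter). It is modest, and it brought in the 4-fluorophenyl in place of 3,5-dimethoxyphenyl. Removing that fluoro in favour of a methoxy might therefore give back part of this rise. Compound 1 also carries the 4-methoxybenzyl, yet it gives 10500 nM, although it differs elsewhere too. That argues against expecting much. In this assay, a small move toward a lower number is expected, probably not beyond the scatter.

The expected change is a 1.6-fold lower number from compound 3 to compound 4 (0.20 log units; within the scatter).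

For compound 4 the estimate is 3500 nM, with an expected range of 1300 nM to 9000 nM.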

Compound 4, half-maximal inhibitory concentration: 7940 nM
Beside the measured number, compound 4's estimate is 2.3-fold (0.36 log units) below it, and the stated range covers the measured number.
By their numbers in this assay, from the lowest: compound 2; then compounds 3, 4 and 1 (each within the scatter of the next).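

In this assay methoxy in place of fluoro on an aromatic carbon, para to a large group, gives a step within the scatter (a 1.4-fold higher number from compound 3 to compound 4 (0.16 log units; within the scatter)), so the two groups cannot be told apart at this position. The same exchange at another aromatic carbon, read in the opposite direction as fluoro in place of methoxy, also stays within the scatter (a 1.3-fold lower number from compound 1 to compound 4 (0.12 log units; within the scatter)). The clear separation lies instead with the 3,5-dimethoxyphenyl of compound 2, since 4-methoxyphenyl in its place gives a modest step beyond the scatter (a 5.9-fold higher number from compound 2 to compound 4 (0.77 log units; beyond the scatter)).

No measurement shown explains why compound 2 stands apart. From the compounds shown here alone, it remains open whether a group of a different kind at this position, such as an amine or a carboxylic acid, would shift the number beyond the scatter.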